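From Methyl to Trifluoromethyl on a Shared Core

The source may report more compounds than this note shows. Statements on the series, on what has been measured and on what is new or still open speak of the compounds shown alone.

In an ADME assay on microsomes from liver (Rattus norvegicus) for metabolic stability (on this read-out lower numbers stand for a shorter-lived compound and higher numbers for a longer-lived compound), compound 1 `CN1C(=O)COc2cc(Nc3ccc4ncn(CC5CC5)c4n3)cnc21` gives 0.117 h as its half-life. Going by the values given here, compound 2 `Cc1cc(Nc2cnc3c(c2)OCC(=O)N3C)nc2c1ncn2CC1CC1` carries a methyl in place of hydrogen on an aromatic carbon and gives 0.367 h, the higher of the two numbers so far. The measured move is a 3.1-fold higher number from compound 1 to compound 2 (0.50 log units; beyond the scatter), a modest step.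

Compound 3 `CN1C(=O)COc2cc(Nc3cc(C(F)(F)F)c4ncn(CC5CC5)c4n3)cnc21` keeps the core of compound 2 and exchanges one group: trifluoromethyl in place of methyl on an aromatic carbon, opposite the ring nitrogen.

Among the compounds with values here, only one measured step bears on this change. It involves the same carbon, but hydrogen rather than trifluoromethyl stands on one side of it, so it offers indirect guidance. Within the data shown here, no measured compound carries a trifluoromethyl, and the data therefore cannot fix the direction firmly. With so little to go on, no step beyond the scatter is confidently expected, and the estimate is a 1.4-fold higher number from compound 2 to compound 3 (0.13 log units; within the scatter) in this assay. For compound 3 the expected half-life is 0.5 h, with an estimated range from 0.22 h to 1.2 h for repeated measurements.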

Compound 3, half-life: 1.12 h
Estimate against measurement, compound 3: 2.2-fold (0.35 log units) below, and the stated range covers the measured number.
By their numbers in this assay, from the lowest: compound 1; then compound 2; then compound 3.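

At this aromatic carbon, opposite the ring nitrogen, methyl did not mark the end of the gain seen with the first substitution: in this assay the exchange for trifluoromethyl gives a 3.1-fold higher number from compound 2 to compound 3 (0.48 log units; beyond the scatter) and so adds a second step beyond the scatter to the earlier one, a 3.1-fold higher number from compound 1 to compound 2 (0.50 log units; beyond the scatter). Taken across the whole change from hydrogen, the position gives a 9.6-fold higher number from compound 1 to compound 3 (0.98 log units; beyond the scatter), so a single site on the shared core spans the full range of half-lives seen so far, and among these three compounds the order runs from hydrogen through methyl to trifluoromethyl with none going against it. Why the half-life rises along this series cannot be said, as nothing shown here speaks to the reason.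

Three compounds cannot show whether the rise follows from the added atoms or from something particular to trifluoromethyl, and an ethyl group, a methoxy group, a chlorine atom or a nitrile on the same carbon would help to separate these readings. As far as these compounds go, it also remains open whether trifluoromethyl would bring a similar step with another group in place of the cyclopropylmethyl chain.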